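Coumarin ester series: aryl swap on the pyrazole carbon

The source may report more compounds than this note shows. Statements on the series, on what has been measured and on what is new or still open speak of the compounds shown alone.

Measured so far:
compound 1, `COc1cc2ccc(=O)oc2cc1OC(=O)c1c(C)noc1-c1ccccc1F`, > 25000 nM
compound 2, `COc1cc2ccc(=O)oc2cc1OC(=O)c1c(-c2ccc(Cl)cc2)n[nH]c1C`, 17100 nM

Among the compounds with values here, in a functional assay on SW-620 cells (Homo sapiens) for inhibition, read by MTT assay, with a stated time of 48 h (a higher number here means a weaker inhibitor, a lower number a stronger inhibitor), compound 2 gives 17100 nM, the only numerical value in hand. For compound 1 the result in this assay is a limit, > 25000 nM, and not a number (the limit of > 25000 nM in this assay, at which 1 of the 2 values shown sits). Compound 3, `COc1cc2ccc(=O)oc2cc1OC(=O)c1c(-c2ccccc2F)n[nH]c1C`, carries 2-fluorophenyl in place of 4-chlorophenyl on an aromatic carbon. Within the data shown here, no measured step of this kind exists in the set. A modest move toward weaker inhibition is expected, probably not beyond the usual scatter, since compound 1 with the same 2-fluorophenyl group only reached > 25000 nM. Compound 3 is estimated at 24000 nM, range 10000 nM to 60000 nM, which is an expected step of a 1.4-fold higher number from compound 2 to compound 3 (0.15 log units; within the scatter).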

Compound 3, half-maximal inhibitory concentration: > 25000 nM
Compound 3 gave a limit, no number; the forecaster's own chance of this, stated with the estimate: 45%; at least 1.0-fold (0.01 log units) between middle value and limit.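

In this assay, 2-fluorophenyl in place of 4-chlorophenyl on this aromatic carbon gives an at least 1.4-fold higher number from compound 2 to compound 3 (0.16 log units; that floor lies within the scatter). Compound 3 gives a limit and not a number, so this step has a floor but no measured size. Compound 2 remains the only compound with a numerical value, and the other two stand at the same limit: the limit of > 25000 nM in this assay, at which 2 of the 3 values shown sit.

The compounds shown do not separate the identity of the halogen from its place on the phenyl ring, a question that 4-fluorophenyl or 2-chlorophenyl would address. Also open, on these data alone, is how an amine or a carboxylic acid on that phenyl ring would read in this assay.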